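Benzylamino in Place of Pyrrolidinyl on a Shared Core

The source may report more compounds than this note shows. Statements on the series, on what has been measured and on what is new or still open speak of the compounds shown alone.

Measured compounds:
compound 1 `Nc1sc(-c2ccccc2)c(-c2ccc(Cl)cc2)c1C(=O)NC1CC1` — 17100 nM
compound 2 `Nc1sc(-c2ccccc2)c(-c2ccc(Cl)cc2)c1C(=O)N1CCCC1` — 22200 nM

Within the data shown here, in a functional assay on PC-3 cells (Homo sapiens) for cytotoxicity, read by sulforhodamine B assay, with a stated time of 72 h (on this read-out higher numbers stand for weaker inhibition and lower numbers for stronger inhibition), compound 2 gives 22200 nM, the higher of the two numbers measured so far; its nearest neighbour is compound 1, and the difference between them lies within the scatter. Compound 3 `Nc1sc(-c2ccccc2)c(-c2ccc(Cl)cc2)c1C(=O)NCc1ccccc1` differs from compound 2 by benzylamino in place of pyrrolidin-1-yl on a carbonyl carbon. Among the measured compounds shown here, the one measured step at the same carbonyl carbon, a 1.3-fold higher number from compound 1 to compound 2 (0.11 log units; within the scatter), changed little, so a further exchange of the group on that carbon is expected to move the number little in this assay. Compound 3 is therefore estimated at 19000 nM (range 7000 nM to 50000 nM), a step of a 1.2-fold lower number from compound 2 to compound 3 (0.07 log units; within the scatter) that is expected to stay within the scatter.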

Compound 3, half-maximal inhibitory concentration: 22800 nM
Compound 3: the middle estimate sits 1.2-fold (0.08 log units) below what was measured; the measured number falls inside the stated range.
By their numbers in this assay, from the lowest: compounds 1, 2 and 3 (each within the scatter of the next).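

In this assay, benzylamino in place of pyrrolidin-1-yl gives a 1.0-fold higher number from compound 2 to compound 3 (0.01 log units; within the scatter) and benzyl in place of cyclopropyl on the amide-type nitrogen gives a 1.3-fold higher number from compound 1 to compound 3 (0.12 log units; within the scatter) in the same measure. A group with a six-membered aromatic ring on this carbonyl carbon thus cannot be told apart from the two groups without one, and all three compounds lie within the scatter of one another. Nothing available bears on why these numbers stay together. The compounds shown leave open whether a morpholine ring, a carboxylic acid or a longer alkyl chain on that carbon would move the number. They also leave open whether any such group would matter on a different core.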